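A Cyano Group Enters the Pendant Phenyl Ring

This account rests on a few compounds, and the source may have more. Where it says the series, first, only, none or still open, it means among the compounds named here.

Compound 1 `C=CC(=O)N1C(=O)CC(c2cccc(Cl)c2)Sc2ccccc21`: 47100 nM in a functional assay on Raji cells (Homo sapiens) for cytotoxicity, read by CCK-8 assay, with a stated time of 24 h; on this read-out lower numbers stand for stronger inhibition and higher numbers for weaker inhibition
Compound 2 `C=CC(=O)N1C(=O)CC(c2ccccc2)Sc2ccccc21`: 74100 nM in this assay

Within the data shown here, compound 2 holds the highest of the two numbers measured so far, and its nearest neighbour is compound 1, whose number is lower by an amount that stays within the scatter. Among the measured compounds shown here, the only step measured between these compounds, a 1.6-fold higher number from compound 1 to compound 2 (0.20 log units; within the scatter), is the one that bears on the new case: it exchanges a substituent on the pendant ring for hydrogen and does not move the read-out beyond the scatter.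

Compound 3 `C=CC(=O)N1C(=O)CC(c2ccc(C#N)cc2)Sc2ccccc21` differs from compound 2 by cyano in place of hydrogen on an aromatic carbon. For the measured compounds named here, since the one measured step on this ring stayed within the scatter, compound 3 is expected to show a step of a 1.2-fold lower number from compound 2 to compound 3 (0.09 log units; within the scatter) from compound 2, which is small. Compound 3 is therefore estimated at 60000 nM, within a range from 25000 nM to 150000 nM.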

Compound 3, half-maximal inhibitory concentration: 84500 nM
Estimate against measurement, compound 3: 1.4-fold (0.15 log units) below; the range from low to high includes it.
By their numbers in this assay, from the lowest: compounds 1, 2 and 3 (each within the scatter of the next).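

In this assay the change from phenyl to 4-cyanophenyl, para to a large group, gives a 1.1-fold higher number from compound 2 to compound 3 (0.06 log units; within the scatter) and so leaves the read-out within the scatter. Until now only a chloro group had been compared with hydrogen on this ring, so a cyano group adds a second substituent, of a different kind and at a different place, with no step beyond the scatter. The exchange of 3-chlorophenyl for 4-cyanophenyl gives a 1.8-fold higher number from compound 1 to compound 3 (0.25 log units; within the scatter) and also stays within the scatter, so the three pendant rings are not told apart on this read-out.

Nothing at hand bears on why these numbers stay so close. From the compounds shown here alone, whether an amine or a carboxylic acid on the pendant ring would move the read-out beyond the scatter remains open.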